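Methoxy on the benzyl amide of compound 2

A few compounds are considered here, and "the series" means these few. Any claim that something is new, unique, unknown or untested is made for them only; others in the source may bear on it.

Values so far in an ADME assay on J774.1 cells (Mus musculus) for cytotoxicity, read by resazurin assay, with a stated time of 48 h; on this read-out higher numbers stand for weaker inhibition and lower numbers for stronger inhibition:
- compound 1 `CCCCn1cc(C(=O)O)c(=O)c2cc(F)c(Cl)cc21`: > 100000 nM, a limit of the assay
- compound 2 `CCCn1cc(C(=O)NCc2ccccc2)c(=O)c2cc(F)c(N3CCC(C(N)=O)CC3)cc21`: 43700 nM, a measured number

For the measured compounds named here, compound 2 holds the only actual number in this small set, so there is no second number to rank it against. Compound 3 `CCCn1cc(C(=O)NCc2ccc(OC)cc2)c(=O)c2cc(F)c(N3CCC(C(N)=O)CC3)cc21` differs from compound 2 in one place: methoxy in place of hydrogen on an aromatic carbon, which turns the benzyl group into 4-methoxybenzyl. Going by the values given here, no measured pair in this assay shows what this kind of change does. The working expectation is therefore no shift beyond the usual scatter and no favoured direction, with the reading staying near that of compound 2 at 43700 nM in this series. Expected here is a 1.0-fold higher number from compound 2 to compound 3 (0.01 log units; within the scatter), a small step. For compound 3 the estimate is 45000 nM, with the expected range running from 20000 nM to 100000 nM for a single measurement.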

Compound 3, half-maximal inhibitory concentration: 41400 nM
Compound 3: middle estimate off by 1.1-fold (0.04 log units), on the high side; measured number inside the range.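

In this assay, for the compounds shown here, this is the first measured pair for the change, and it gives a 1.1-fold lower number from compound 2 to compound 3 (0.02 log units; within the scatter). On this read-out, methoxy in place of hydrogen on an aromatic carbon, which turns benzyl into 4-methoxybenzyl, does not separate the two compounds at this position, para to a large group. Both compounds give real numbers, so the step is read between two numbers, and neither compound sits at the limit of the assay: the limit of > 100000 nM in this assay, at which 1 of the 3 values shown sits.

A single pair leaves open whether other groups at this place, such as an amine, a carboxylic acid or a longer alkoxy chain, would also stay within the scatter. Also open, as far as these compounds go, is whether methoxy would behave the same way on the same ring at another carbon, or with a longer chain in place of the propyl group on the shared core.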